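The compounds below may be only part of what the source reports. "The series", "measured", "known", "first", "only" and "open" are said of these compounds alone.

Three compounds have been measured in a functional assay on WRL68 cells (Homo sapiens) for cytotoxicity, read by colony formation; on this read-out lower numbers stand for stronger inhibition and higher numbers for weaker inhibition:

- compound 1 `COC(=O)C1=CO[C@@H](O[C@@H]2O[C@H](COC(c3ccccc3)(c3ccccc3)c3ccccc3)[C@@H](O)[C@H](O)[C@H]2O)[C@@H]2[C@@H](C)[C@@H](O)C[C@H]12` gives 4.2 ug/mL
- compound 2 `COC(=O)C1=CO[C@@H](O[C@@H]2O[C@H](COC(c3ccccc3)(c3ccccc3)c3ccccc3)[C@@H](OC(=O)O)[C@H](OC(C)=O)[C@H]2OC(C)=O)[C@@H]2[C@@H](C)[C@@H](OC(C)=O)C[C@H]12` gives 1.86 ug/mL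
- compound 3 `CCC(=O)OC[C@H]1O[C@@H](O[C@@H]2OC=C(C(=O)OC)[C@H]3C[C@H](OC(C)=O)[C@H](C)[C@@H]23)[C@H](OC(C)=O)[C@@H](OC(C)=O)[C@@H]1OC(C)=O` gives 8.4 ug/mL

Compound 3 has the highest number of the three only in relation to compound 2, whose value (1.86 ug/mL) lies lower by more than the usual scatter. Compound 3 (8.4 ug/mL) cannot be separated from compound 1 (4.2 ug/mL), since those two values fall within the scatter of each other.

The next compound, compound 4 `CCCCCCCCCCCC(=O)OC[C@H]1O[C@@H](O[C@@H]2OC=C(C(=O)OC)[C@H]3C[C@H](OC(C)=O)[C@H](C)[C@@H]23)[C@H](OC(C)=O)[C@@H](OC(C)=O)[C@@H]1OC(C)=O`, departs from compound 3 by a single change: nonyl in place of hydrogen on a saturated chain carbon, two bonds along the chain from a carbonyl carbon. For the measured compounds named here, no two measured compounds differ in only one place, so the data give no direct measure of what such a change does in this assay. The expectation therefore stays anchored on compound 3 (8.4 ug/mL), with no step beyond the scatter and no firm direction. The expected change is small, a 1.1-fold higher number from compound 3 to compound 4 (0.03 log units; within the scatter), and remains uncertain. Compound 4 is estimated at 9 ug/mL, within an expected range of 3.5 ug/mL to 25 ug/mL, in this measurement.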

Compound 4, half-maximal inhibitory concentration: 2.62 ug/mL
Compound 4: middle estimate off by 3.4-fold (0.54 log units), on the high side; the measured number lies below the stated range.
By their numbers in this assay, from the lowest: compounds 2, 4, 1 and 3 (each within the scatter of the next, the first and the last beyond it).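

In this assay, the first step readable between two compounds that differ in one place is a 3.2-fold lower number from compound 3 to compound 4 (0.51 log units; beyond the scatter), with nonyl in place of hydrogen on a saturated chain carbon, two bonds along the chain from a carbonyl carbon. It shows that this position is not silent: the added chain moves the number beyond the scatter toward stronger inhibition, so the nonyl group is accepted here with no loss of inhibition in this cell read-out. Nothing among the data speaks to what lies behind this shift, so the step stands as a bare observation.

A single step gives one point and no trend, so the compounds shown leave open whether the number depends on chain length at all, and whether a shorter chain such as butyl or a longer one such as tetradecyl on the same carbon would give a lower or a higher number. They also leave open whether the chain itself matters or whether a different group there, such as an amine, a carboxylic acid or a phenyl group, would shift the number in the same direction.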